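The source may hold more compounds than are shown below. What is called first, only, known or untested is meant among the compounds shown, and "the series" means these compounds.

The measured compounds are:
compound 1 `Fc1ccc(-c2ccc3c(NCCCNCc4ccco4)ccnc3c2)cc1`, which in a physicochemical assay for solubility, with a stated time of 18 h, at pH 7.4 (a lower number here means a less soluble compound, a higher number a more soluble compound), gives 32000 nM
compound 2 `Cc1cc(C)cc(Cc2ccc3c(NCCCNCc4ccco4)ccnc3c2)c1`, which in this assay gives 4200 nM

Within the data shown here, compound 2 stands at the lowest of the two numbers; its nearest neighbour is compound 1, and the single measured step, a 7.6-fold lower number from compound 1 to compound 2 (0.88 log units; beyond the scatter), lies beyond the scatter. Compound 3 `COc1cccc(Oc2ccc3c(NCCCNCc4ccco4)ccnc3c2)c1` differs from compound 2 in one place: 3-methoxyphenoxy in place of 3,5-dimethylbenzyl on an aromatic carbon. Among the measured compounds shown here, no measured step changes this same position in this same way, so the step from compound 1 to compound 2 bears on it only as a guide to how much this position can move the number. A group with two hydrogen-bond acceptors enters where a carbon-only group leaves, and compound 3 is therefore expected to move back upward in this assay, by a 2.4-fold higher number from compound 2 to compound 3 (0.38 log units; beyond the scatter), a step of modest size. The estimate for compound 3 is 10000 nM, with a range from 3000 nM to 35000 nM.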

Compound 3, solubility: 14500 nM
The estimate for compound 3 lay 1.5-fold (0.16 log units) below the measured number; measured number inside the range.
By their numbers in this assay, from the lowest: compound 2; then compound 3; then compound 1.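

In this assay, replacing 3,5-dimethylbenzyl with 3-methoxyphenoxy gives a 3.5-fold higher number from compound 2 to compound 3 (0.54 log units; beyond the scatter) and shows that this position can also move the number upward, recovering part of the earlier drop. The recovery is incomplete, with a 2.2-fold lower number from compound 1 to compound 3 (0.34 log units; beyond the scatter) still separating the two compounds, so 3-methoxyphenoxy lies between 4-fluorophenyl and 3,5-dimethylbenzyl at this position. The entering and leaving groups have the same number of heavy atoms and each has one aromatic ring of carbon only, so this step comes with oxygen taking the place of carbon and no change in group size, but nothing at hand explains it.

The compounds shown do not separate the contribution of the linking oxygen from that of the methoxy group. They also leave open whether an amine or a carboxylic acid at this position would raise the number past that of compound 1.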